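The source may report more compounds than this note shows. Statements on the series, on what has been measured and on what is new or still open speak of the compounds shown alone.

Working notes on the amide series. The three measured compounds share one core and differ only in the aryl on the carbonyl carbon. Compound 1 `O=C(Nc1cccc(-c2oc3cc(-c4ccc(F)cc4)ccc3c(=O)c2O)c1)c1ccc(F)cc1` gives 16000 nM in a functional assay on MDA-MB-231 cells (Homo sapiens) for antiproliferative activity, read by CCK-8 assay, with a stated time of 72 h; on this read-out higher numbers stand for weaker inhibition and lower numbers for stronger inhibition. Compound 2 `O=C(Nc1cccc(-c2oc3cc(-c4ccc(F)cc4)ccc3c(=O)c2O)c1)c1ccc(F)cc1F` gives 11200 nM in this assay; the step of a 1.4-fold lower number from compound 1 to compound 2 (0.15 log units; within the scatter) is within the scatter. Compound 3 `Cc1ccccc1C(=O)Nc1cccc(-c2oc3cc(-c4ccc(F)cc4)ccc3c(=O)c2O)c1` gives 4910 nM in this assay, the lowest of the three numbers; the steps of a 3.3-fold lower number from compound 1 to compound 3 (0.51 log units; beyond the scatter) and a 2.3-fold lower number from compound 2 to compound 3 (0.36 log units; beyond the scatter) are both beyond the scatter, though modest in size.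

Compound 4 `COc1cccc(C(=O)Nc2cccc(-c3oc4cc(-c5ccc(F)cc5)ccc4c(=O)c3O)c2)c1` has not yet been measured in this assay. It differs from compound 3 by 3-methoxyphenyl in place of 2-methylphenyl on a carbonyl carbon. Going by the values given here, the steps that bear on this change are a 3.3-fold lower number from compound 1 to compound 3 (0.51 log units; beyond the scatter) and a 2.3-fold lower number from compound 2 to compound 3 (0.36 log units; beyond the scatter), since each of them also exchanges the aryl on the carbonyl carbon; both show that such exchanges move the number by modest amounts only. Among the compounds with values here, no measured pair sets 2-methylphenyl against 3-methoxyphenyl, so the direction of the coming step is not fixed by the data. A modest step, most likely back toward the numbers of compound 1 and compound 2, is expected. Compound 4 is estimated at 8000 nM, with a range from 3000 nM to 25000 nM. The expected step is a 1.6-fold higher number from compound 3 to compound 4 (0.21 log units; within the scatter).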

Compound 4, half-maximal inhibitory concentration: 9160 nM
Beside the measured number, compound 4's estimate is 1.1-fold (0.06 log units) below it, and the stated range covers the measured number.
By their numbers in this assay, from the lowest: compounds 3, 4, 2 and 1 (each within the scatter of the next, the first and the last beyond it).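

this assay now has its first aryl on the carbonyl carbon that carries an oxygen, and 3-methoxyphenyl gives three steps that all lie within the scatter (a 1.9-fold higher number from compound 3 to compound 4 (0.27 log units; within the scatter)) (a 1.2-fold lower number from compound 2 to compound 4 (0.09 log units; within the scatter)) (a 1.7-fold lower number from compound 1 to compound 4 (0.24 log units; within the scatter)), so compound 4 cannot be set apart from any of the other three compounds. Compound 3 still stands apart from compound 1 and compound 2, but compound 4 does not share that separation, and the one hydrogen-bond acceptor counted on the entering group brings no step beyond the scatter. Across these four compounds, every exchange of aryl on this carbonyl carbon stays modest or within the scatter, with no compound going against that, while nothing in hand accounts for the numbers.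

The pairs shown do not separate the kind of substituent from where it sits, and 3-methylphenyl and 2-methoxyphenyl would be the groups to read that. Also open, from the compounds shown here alone, is whether this position stays as flat with an amine or a carboxylic acid on the aryl, or with a longer alkyl chain in place of the aryl.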